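From 2-methoxyphenyl to 4-methoxyphenyl: a small expected step

The source may hold more compounds than are shown below. What is called first, only, known or untested is meant among the compounds shown, and "the series" means these compounds.

Compound 1 `COc1ccccc1NC(=S)NNC(=O)CSCc1cc(C(C)(C)C)c(O)c(C(C)(C)C)c1`: 52000 nM
Compound 2 `COc1ccccc1Nc1nnc(CSCc2cc(C(C)(C)C)c(O)c(C(C)(C)C)c2)s1`: 90800 nM

Both numbers come from a physicochemical assay, read by spectrophotometry, with a stated time of 60 min; on this read-out higher numbers stand for weaker inhibition and lower numbers for stronger inhibition. There, compound 1 gives 52000 nM and compound 2 gives 90800 nM. These two values lie within the usual scatter of each other, so compound 1 does not stand apart from compound 2 on these numbers.

The next compound, compound 3 `COc1ccc(NC(=S)NNC(=O)CSCc2cc(C(C)(C)C)c(O)c(C(C)(C)C)c2)cc1`, has not yet been measured in this assay. It keeps the rest of compound 1 and carries 4-methoxyphenyl in place of 2-methoxyphenyl on an amide-type nitrogen. The two compounds have the same atoms, joined differently.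

For the measured compounds named here, no two measured compounds differ in one place only, so the data offer no direct precedent for this change. The expectation therefore starts from compound 1 at 52000 nM and assumes no shift beyond the scatter. The expected step is a 1.2-fold lower number from compound 1 to compound 3 (0.06 log units; within the scatter). For compound 3 the estimated value is 45000 nM, with an expected range from 18000 nM to 110000 nM.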

Compound 3, half-maximal inhibitory concentration: 50900 nM
Compound 3: the middle estimate sits 1.1-fold (0.05 log units) below what was measured; low and high end bracket the measured number.
By their numbers in this assay, from the lowest: compounds 3, 1 and 2 (each within the scatter of the next).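

In this assay, placing 4-methoxyphenyl in place of 2-methoxyphenyl on an amide-type nitrogen, whose other neighbour is the thiocarbonyl carbon, gives a 1.0-fold lower number from compound 1 to compound 3 (0.01 log units; within the scatter). For the compounds shown here, the earlier compounds offered no pair differing in one place only, so this is the only direct reading at this position, and it shows that these two groups, with the same atoms joined differently, are not told apart on this read-out. No measured property is available that could account for this result.

The compounds shown leave open how this position responds to a group other than a methoxyphenyl, such as a phenyl ring carrying an amine or a carboxylic acid, or a longer chain in place of the methoxy group. Going by these compounds, whether 4-methoxyphenyl in place of 2-methoxyphenyl reads the same way on the core of compound 2 also stays open.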